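From a benzyl amide to a chlorophenyl amide

The compounds below may be only part of what the source reports. "The series", "measured", "known", "first", "only" and "open" are said of these compounds alone.

In a functional assay on A549 cells (Homo sapiens) for cytotoxicity, read by MTT assay, with a stated time of 48 h (on this read-out lower numbers stand for stronger inhibition and higher numbers for weaker inhibition), compound 3 `CCOC(=O)[C@]1(C(=O)NCc2ccc(C)cc2)C[C@H]1c1cc(OC)c(OC)c(OC)c1` gives 13300 nM as its reading. Compound 1 `COc1cc([C@@H]2C[C@]2(CO)C(=O)Nc2ccccc2Cl)cc(OC)c1OC` gives 4400 nM in this assay, a lower number by a gap beyond the usual scatter, so compound 3 is the weaker of that pair. Compound 2 `CCOC(=O)C1(C(=O)Nc2ccccc2Cl)CC1c1cc(OC)c(OC)c(OC)c1` has two entries, 18000 nM; 18500 nM (2 entries), and these lie within the scatter of compound 3.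

Compound 4 `CCOC(=O)[C@]1(C(=O)Nc2ccccc2Cl)C[C@H]1c1cc(OC)c(OC)c(OC)c1` has not been measured yet. It has 2-chlorophenyl in place of 4-methylbenzyl on an amide-type nitrogen. Among the measured compounds shown here, no measured pair isolates this change, so the expectation leans on compound 2, which also carries 2-chlorophenyl and gives 18000 nM; 18500 nM (2 entries) on its amide. Compound 1 goes against this guide: it carries the same group, differs elsewhere, and gives 4400 nM as its reading.

A small move towards weaker inhibition is expected, within the scatter, and the estimated step is a 1.2-fold higher number from compound 3 to compound 4 (0.08 log units; within the scatter) in size. Compound 4 is estimated at 16000 nM, with an expected range from 8000 nM to 30000 nM in this assay.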

Compound 4, half-maximal inhibitory concentration: 13400 nM
Compound 4: the middle estimate sits 1.2-fold (0.08 log units) above what was measured; the measured number falls inside the stated range.
By their numbers in this assay, from the lowest: compound 1; then compounds 3 and 4 (each within the scatter of the next).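

Swapping 4-methylbenzyl for 2-chlorophenyl on the amide-type nitrogen leaves no readable difference in this assay: the step is a 1.0-fold higher number from compound 3 to compound 4 (0.00 log units; within the scatter), so at this position the two groups cannot be told apart. With 2-chlorophenyl on the amide in both compounds, ethoxycarbonyl in place of hydroxymethyl on a saturated ring carbon gives a 3.0-fold higher number from compound 1 to compound 4 (0.48 log units; beyond the scatter), which ties the lower number of compound 1 to that ring-carbon group and not to its amide group. The higher readings of compound 2 are a limited guide to compound 4, and one fact stands in the way of reading that gap: the fact that one of compounds 2 and 4 is drawn with a defined configuration and the other without, at the place where they differ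

On these data alone, it remains open whether a plain cyclohexyl group or a longer alkyl chain on the amide would also leave the number unchanged. Also open, as far as these compounds go, is how a carboxylic acid or a primary amide would compare with ethoxycarbonyl and hydroxymethyl on the ring carbon.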